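Working notes on an ester variation in a chlorinated lactone series

The compounds below may be only part of what the source reports. "The series", "measured", "known", "first", "only" and "open" are said of these compounds alone.

Measured compounds in a functional assay on A549 cells (Homo sapiens) for inhibition, read by MTT assay; a higher number here means a weaker inhibitor, a lower number a stronger inhibitor:
compound 1 `C=C1/C=C/[C@H](OC(C)=O)[C@@]2(C)[C@@H](OC(C)=O)[C@@H](OC(C)=O)[C@@H](OC(C)=O)[C@]3(CO3)[C@@H]2[C@H](OC(C)=O)[C@]2(O)[C@@H](C)C(=O)O[C@H]2[C@H]1Cl` gives 8400 nM
compound 2 `C=C1/C=C/[C@H](OC(C)=O)[C@@]2(C)[C@@H](OC(C)=O)C[C@@H](OC(C)=O)[C@]3(CO3)[C@@H]2[C@H](OC(C)=O)[C@]2(O)[C@@H](C)C(=O)O[C@H]2[C@H]1Cl` gives 47300 nM

For the measured compounds named here, compound 2 stands highest of the two numbers; the single measured step, a 5.6-fold higher number from compound 1 to compound 2 (0.75 log units; beyond the scatter), separates it from compound 1 and lies beyond the scatter. Compound 3 `C=C1/C=C/[C@H](OC(C)=O)[C@@]2(C)[C@@H](OC(C)=O)C[C@@H](OC(=O)CC(C)C)[C@]3(CO3)[C@@H]2[C@H](OC(C)=O)[C@]2(O)[C@@H](C)C(=O)O[C@H]2[C@H]1Cl` differs from compound 2 in one place: isopropyl in place of hydrogen on a saturated chain carbon bound to a carbonyl carbon. Going by the values given here, no measured step bears directly on this change. Among the compounds with values here, the one step in the set removes an acetoxy group from a saturated ring carbon altogether, whereas the change to compound 3 keeps the ester and extends its acyl part, acetyl to isobutylcarbonyl. The measured step shows that the acetoxy group itself matters, but it gives no reading on how a larger acyl group would behave. With nothing to anchor a direction, the expected step of a 1.6-fold lower number from compound 2 to compound 3 (0.20 log units; within the scatter) is judged small, at most around the scatter, with a slight lean toward a lower number. Compound 3 is therefore estimated at 30000 nM in this assay, with a range from 8000 nM to 110000 nM.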

Compound 3, half-maximal inhibitory concentration: 20600 nM
Compound 3: the middle estimate sits 1.5-fold (0.16 log units) above what was measured, within the range that was stated.
By their numbers in this assay, from the lowest: compound 1; then compound 3; then compound 2.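

In this assay, taking the ester at this position from acetoxy to (isobutylcarbonyl)oxy gives a 2.3-fold lower number from compound 2 to compound 3 (0.36 log units; beyond the scatter), so the larger acyl part is tolerated here and the number moves down rather than up. For the compounds shown here, the earlier step, a 5.6-fold higher number from compound 1 to compound 2 (0.75 log units; beyond the scatter), removed an acetoxy group outright, whereas this change keeps the ester in place and gives the first reading on its acyl part, showing that the acyl part alone can shift the number beyond the scatter. Nothing at hand accounts for the size or the direction of this step.

With only acetyl and isobutylcarbonyl at this position, two points fix no trend, and a free hydroxyl, a longer chain such as octanoyl, or an aromatic ester such as benzoyl would show whether the number keeps falling, levels off or turns back up. As far as these compounds go, it also remains open whether the same change from acetyl to isobutylcarbonyl would give a step of similar direction and size on the core of compound 1, which carries the additional acetoxy group on a saturated ring carbon.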